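Biaryl anilides as vanilloid channel antagonists: anilide substituent

This account rests on a few compounds, and the source may have more. Where it says the series, first, only, none or still open, it means among the compounds named here.

Measured compounds:
compound 1, `O=C(Nc1ccccc1)c1ccc(-c2ncccc2C(F)(F)F)cc1` — > 4000 nM
compound 2, `Cc1cccnc1-c1ccc(C(=O)Nc2ccc(C(C)C)cc2)cc1` — 73 nM

For the measured compounds named here, in a functional assay for antagonist activity at transient receptor potential cation channel subfamily V member 1 (Homo sapiens), read by FLIPR (a lower number here means a stronger inhibitor, a higher number a weaker inhibitor), compound 1 gives only a limit, > 4000 nM, not a number; compound 1 is the one value that sits at the limit of > 4000 nM in this assay, at which 1 of the 2 values shown sits. In this assay, going by the values given here, compound 2 gives 73 nM, the only actual number in the set so far, and the two measured compounds differ in more than one place, so no single step between them can be read off; their two values show only that compound 2 is a measurable inhibitor while compound 1 is not resolved.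

Compound 3, `Cc1cccnc1-c1ccc(C(=O)Nc2ccc(Cl)cc2)cc1`, is not yet measured. It differs from compound 2 as follows: chloro in place of isopropyl on an aromatic carbon. Among the compounds with values here, no measured step informs this exchange directly, so the expectation rests on compound 2 alone and on the size of the group that leaves versus the one that enters. For compound 3 in this assay a modest loss is expected, a step of a 2.7-fold higher number from compound 2 to compound 3 (0.44 log units; beyond the scatter) from compound 2, estimated at 200 nM with a range of 60 nM to 700 nM.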

Compound 3, half-maximal inhibitory concentration: 1500 nM
Compound 3: the middle estimate sits 7.5-fold (0.88 log units) below what was measured, outside the stated range (above it).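

In this assay, for the compounds shown here, chloro in place of isopropyl on an aromatic carbon, para to a large group, gives a 21-fold higher number from compound 2 to compound 3 (1.31 log units; beyond the scatter), a large step and the first single-place comparison. With the rest of compound 2 unchanged, the whole step belongs to this one place, where 3 heavy atoms leave and 1 enters, so this position is sensitive to the group it carries. The values shown give no cause for this step.

One pair cannot show which feature of isopropyl matters, and tert-butyl, methoxy or trifluoromethyl at this place would each add a further step from compound 2 to set beside this one. Going by these compounds, compound 1 gives only a limit and differs from compound 2 and compound 3 in more than one place, so it remains open whether the same exchange on the anilide would carry the same weight with the trifluoromethyl group of compound 1 on the other end of the core.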